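Methoxy for chloro: working notes on a small series

The source may report more compounds than this note shows. Statements on the series, on what has been measured and on what is new or still open speak of the compounds shown alone.

Values in a functional assay on MDA-MB-231 cells (Homo sapiens) for antiproliferative activity, with a stated time of 72 h (a lower number here means a stronger inhibitor, a higher number a weaker inhibitor), so far:
compound 1 `COc1ccc(C2CC(c3ccc(Cl)cc3)=NN2c2nc(-c3ccccc3)c(C#N)c(=O)n2C)cc1` — 11100 nM
compound 2 `COc1ccc(C2=NN(c3nc(-c4ccccc4)c(C#N)c(=O)n3C)C(c3ccc(OC)cc3)C2)cc1` — 16200 nM
compound 3 `COc1ccc(C2CC(c3ccc(Cl)cc3)=NN2c2nc(-c3ccc(Cl)cc3)c(C#N)c(=O)n2C)cc1` — 24800 nM

Compound 1 and compound 2 differ by methoxy in place of chloro on an aromatic carbon; the step is a 1.5-fold higher number from compound 1 to compound 2 (0.16 log units; within the scatter). Compound 1 and compound 3 differ in the core by chloro in place of hydrogen on an aromatic carbon; that step is a 2.2-fold higher number from compound 1 to compound 3 (0.35 log units; beyond the scatter), and compound 3 stands at the highest number of the three, though it lies within the scatter of compound 2.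

Compound 4 `COc1ccc(C2=NN(c3nc(-c4ccc(Cl)cc4)c(C#N)c(=O)n3C)C(c3ccc(OC)cc3)C2)cc1` has not been measured in this assay. For the measured compounds named here, it differs from compound 3 by methoxy in place of chloro on an aromatic carbon, the same change, at the same place, as the one from compound 1 to compound 2, made here on the core of compound 3. For compound 4 a step of about a 1.5-fold higher number from compound 3 to compound 4 (0.17 log units; within the scatter) is expected, resting on the step of a 1.5-fold higher number from compound 1 to compound 2 (0.16 log units; within the scatter) already seen. Compound 4 is therefore estimated at 37000 nM in this assay. For compound 4 the plausible range is expected to run from 18000 nM to 75000 nM. Compound 3 already sits at the weak end, so compound 4 may return only a limit rather than a number.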

Compound 4, half-maximal inhibitory concentration: 28300 nM
Estimate against measurement, compound 4: 1.3-fold (0.12 log units) above; low and high end bracket the measured number.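

In this assay, the change from 4-chlorophenyl to 4-methoxyphenyl on the core of compound 3 gives a 1.1-fold higher number from compound 3 to compound 4 (0.06 log units; within the scatter), and the two readings of this change agree: the same change on two cores in this assay, a 1.5-fold higher number (0.16 log units; within the scatter) from compound 1 to compound 2 and a 1.1-fold higher number (0.06 log units; within the scatter) from compound 3 to compound 4, 1.3-fold (0.11 log units) apart, within the scatter of two such steps

Chloro in place of hydrogen, read on the methoxy-bearing pair, gives a 1.7-fold higher number from compound 2 to compound 4 (0.24 log units; within the scatter), and its two readings also agree, although only the earlier step lies beyond the scatter: the same change on two cores in this assay, a 2.2-fold higher number (0.35 log units; beyond the scatter) from compound 1 to compound 3 and a 1.7-fold higher number (0.24 log units; within the scatter) from compound 2 to compound 4, 1.3-fold (0.11 log units) apart, within the scatter of two such steps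

For the compounds shown here, the methoxy change therefore carries between these two cores without a detectable difference, but both of its steps lie within the scatter, so this shows no measurable effect of the change on either core and rests on only two cores, which cannot establish transfer across the wider series.

On these data alone, it remains open whether a different group on that aromatic carbon, such as an amine, a carboxylic acid or a longer chain like butoxy, would behave in the same way. As far as these compounds go, it also remains open whether any such group would give a lower number than compound 1 shows.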